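Acyl groups on the aniline nitrogen of the chalcone series

The source may report more compounds than this note shows. Statements on the series, on what has been measured and on what is new or still open speak of the compounds shown alone.

Measured so far:
compound 1 `COc1cc(/C=C/C(=O)c2cccc(N)c2)ccc1O` — 6.02 ug/mL
compound 2 `CCOC(=O)C(=O)Nc1cccc(C(=O)/C=C/c2ccc(O)c(OC)c2)c1` — > 50 ug/mL

In a functional assay on Vero cells (Chlorocebus sabaeus) for inhibition (on this read-out lower numbers stand for stronger inhibition and higher numbers for weaker inhibition), compound 1 gives 6.02 ug/mL. For compound 2 the reading > 50 ug/mL is a limit of the assay and not a number (the limit of > 50 ug/mL in this assay, at which 1 of the 2 values shown sits). Within the data shown here, the single measured step is an at least 8.3-fold higher number from compound 1 to compound 2 (0.91 log units; beyond the scatter), the introduction of (ethoxycarbonyl)carbonyl on the ring nitrogen.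

Compound 3 `CCCC(=O)Nc1cccc(C(=O)/C=C/c2ccc(O)c(OC)c2)c1` differs from compound 2 by propyl in place of ethoxycarbonyl on a carbonyl carbon, so the nitrogen keeps a carbonyl substituent, now propylcarbonyl instead of (ethoxycarbonyl)carbonyl. Among the measured compounds shown here, only the step from compound 1 to compound 2 bears on this, and it covered a different change; no measured pair separates propylcarbonyl from (ethoxycarbonyl)carbonyl. Given that compound 2 sits at > 50 ug/mL, compound 3 is expected to stay weak, with a step of an at least 1.2-fold lower number from compound 2 to compound 3 (0.09 log units; that floor lies within the scatter) in this assay not clearly beyond the scatter. Compound 3 is estimated at 40 ug/mL, between 10 ug/mL and 100 ug/mL.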

Compound 3, half-maximal inhibitory concentration: 2.04 ug/mL
Estimate against measurement, compound 3: 20-fold (1.29 log units) above; measured number outside the range, below it.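

In this assay, an acyl group on the ring nitrogen does not by itself cost inhibition: propylcarbonyl in place of hydrogen gives a 3.0-fold lower number from compound 1 to compound 3 (0.47 log units; beyond the scatter), the opposite direction to an at least 8.3-fold higher number from compound 1 to compound 2 (0.91 log units; beyond the scatter). With the nitrogen carrying a carbonyl in both compounds, propyl in place of ethoxycarbonyl on the carbonyl carbon gives an at least 24-fold lower number from compound 2 to compound 3 (1.38 log units; beyond the scatter), so among these compounds the outcome turns on the group at that carbonyl carbon. That step starts from a limit of the assay and not a number, so only its lower bound is known: the limit of > 50 ug/mL in this assay, at which 1 of the 3 values shown sits.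

Whether the difference follows the propyl chain or the ethoxycarbonyl group cannot be separated here, as one change swaps both. A methyl group, a longer alkyl chain or a carboxylic acid on the same carbonyl carbon would bear on that question.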